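Methoxy on the aryl ring of a thiazolotriazole-type scaffold

A few compounds are considered here, and "the series" means these few. Any claim that something is new, unique, unknown or untested is made for them only; others in the source may bear on it.

Measured so far:
compound 1 `C/C(=N/O)c1ccc(NC(=O)Cn2nc(-c3ccccc3)nc2N)cc1`, 23%
compound 2 `c1ccc(-c2nc3sc(-c4ccccc4)cn3n2)cc1`, 63%

In a functional assay on T47D cells (Homo sapiens) for inhibition, read by sulforhodamine B assay, with a stated time of 48 h, tested at 10 uM (a lower number here means less inhibition of growth, a higher number more inhibition of growth at the concentration tested), compound 2 gives 63%, the higher of the two numbers; compound 1 gives 23%, a gap beyond the usual scatter. Compound 3 `COc1ccc(-c2nc3sc(-c4ccccc4)cn3n2)cc1` is not yet measured. It differs from compound 2 by methoxy in place of hydrogen on an aromatic carbon. Within the data shown here, no measured pair shows this change, so the expected step of a number 3 percentage points lower from compound 2 to compound 3 (within the scatter) is small, in either direction, and probably within the scatter. Compound 3 is therefore estimated at 60%, between 35% and 80%.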

Compound 3, percent growth inhibition at one concentration: 65%
Compound 3: the middle estimate sits 5 percentage points below what was measured; the measured number falls inside the stated range.
By their numbers in this assay, from the lowest: compound 1; then compounds 2 and 3 (each within the scatter of the next).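

In this assay, among these compounds, this pair gives the first direct reading of the change, a number 2 percentage points higher from compound 2 to compound 3 (within the scatter). Methoxy in place of hydrogen on an aromatic carbon, para to a large group, is therefore tolerated at this position, at least at the single concentration tested. Nothing available explains this result. One substituent at one place cannot show whether this position is generally tolerant. As far as these compounds go, whether an amine, a carboxylic acid or a longer chain would be accepted here stays open, as does the effect of methoxy elsewhere on the shared core.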